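The source may hold more compounds than are shown below. What is called first, only, known or untested is meant among the compounds shown, and "the series" means these compounds.

Compound 1 `CN(C)C(=O)c1cc2cnc(Nc3ccc(C(=O)NCCCN=C=S)cc3F)nc2n1C1CCCC1` gave 78.5%.
Compound 2 `CN(C)C(=O)c1cc2cnc(Nc3ccc(C(=O)NCCCCN=C=S)cc3F)nc2n1C1CCCC1` gave 78.9%.
Compound 3 `CN(C)C(=O)c1cc2cnc(Nc3ccc(NC(=O)CCCCCN=C=S)cc3)nc2n1C1CCCC1` gave 85%.

All three were tested in a functional assay on NCI-H1299 cells (Homo sapiens) for inhibition, read by CCK-8 assay, with a stated time of 72 h, tested at 10 uM; a higher number here means a stronger effect of the compound at the concentration tested, a lower number a weaker effect. Compound 1 and compound 2 share a core and differ only at the end of the chain, where (a group of 4 heavy atoms (2 carbon, 1 nitrogen, 1 sulfur; no ring) in place of a group of 3 heavy atoms (1 carbon, 1 nitrogen, 1 sulfur; no ring), on a saturated chain carbon, three bonds along the chain from an amide-type nitrogen); this change produced a number 0.4 percentage points higher from compound 1 to compound 2 (within the scatter). Compound 3 gave 85% in this assay, but the difference between the core of compound 3 and that of compound 1 is not broken down here, so its value is read on its own and not as a step.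

Compound 4 `CN(C)C(=O)c1cc2cnc(Nc3ccc(NC(=O)CCCCCCN=C=S)cc3)nc2n1C1CCCC1` is not yet measured. It differs from compound 3 by a group of 4 heavy atoms (2 carbon, 1 nitrogen, 1 sulfur; no ring) in place of a group of 3 heavy atoms (1 carbon, 1 nitrogen, 1 sulfur; no ring), on a saturated chain carbon, five bonds along the chain from a carbonyl carbon. This is the same kind of change as that from compound 1 to compound 2, but the surroundings differ: in compound 4 it sits five bonds along the chain from a carbonyl carbon, while in compound 2 it sat three bonds along the chain from an amide-type nitrogen. Because the earlier change gave a number 0.4 percentage points higher from compound 1 to compound 2 (within the scatter), the step from compound 3 to compound 4 is expected to be about no change at the digits printed from compound 3 to compound 4 (within the scatter). Compound 4 is therefore estimated at 85%, with a likely range from 73% to 94%.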

Compound 4, a percentage reported as inhibition, at one concentration (the size of the read-out at that concentration, not a potency): 80.9%
Estimate against measurement, compound 4: 4.1 percentage points above; low and high end bracket the measured number.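

On the core of compound 3, the group of 4 heavy atoms in place of the group of 3 heavy atoms gave a number 4.1 percentage points lower from compound 3 to compound 4 (within the scatter). Set beside the same change on the core of compound 1, the two steps cannot be told apart: the same change on two cores in this assay, a number 0.4 percentage points higher (within the scatter) from compound 1 to compound 2 and a number 4.1 percentage points lower (within the scatter) from compound 3 to compound 4, 4.5 percentage points apart, within the scatter of two such steps. This shows that, in this assay, the change has no effect beyond the scatter on either core, but with only one pair of steps, each read at a single concentration, it does not show that the change would behave the same way on other cores in this series, nor does it give a potency for any of these compounds.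

The compounds shown leave open how a longer chain would read on either core. They also leave open what would happen if an amine or a carboxylic acid stood at the end of the chain in place of the sulfur-bearing end group.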